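This account rests on a few compounds, and the source may have more. Where it says the series, first, only, none or still open, it means among the compounds named here.

In a functional assay on HL-60 cells (Homo sapiens) for inhibition, read by CCK-8 assay, with a stated time of 48 h (a lower number here means a stronger inhibitor, a higher number a weaker inhibitor), three compounds of this series have been read. Compound 1 `O=[N+]([O-])c1ccc(NC(=S)NCCNS(=O)(=O)c2ccc(-c3ccccc3OCc3ccccc3)s2)cc1` gives > 50000 nM, which is a limit of the assay and not a number. Compound 3 `Cc1cc(C)cc(NC(=O)NCCNS(=O)(=O)c2ccc(-c3ccccc3OCc3cccc(O)c3)s2)c1` gives > 20000 nM, which is likewise a limit. For the measured compounds named here, compound 2 `O=S(=O)(NCCNC(=S)Nc1cc(C(F)(F)F)cc(C(F)(F)F)c1)c1ccc(-c2ccccc2O[C@H]2CC[C@@H](O)CC2)s1` gives 2600 nM, the only actual number of the three.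

Compound 4 `O=S(=O)(NCCNC(=S)Nc1cc(C(F)(F)F)cc(C(F)(F)F)c1)c1ccc(-c2ccccc2Oc2ccc(O)c(O)c2)s1` has not yet been measured in this assay. It differs from compound 2 in a single group: 3,4-dihydroxyphenyl in place of 4-hydroxycyclohexyl on an oxygen on an aromatic ring. In words, 3,4-dihydroxyphenyl stands in place of 4-hydroxycyclohexyl on an oxygen on an aromatic ring. Going by the values given here, no pair of measured compounds shows what such a swap does, so the only anchor is compound 2 at 2600 nM, and the rest of that structure is kept. On that basis, no change beyond the usual scatter is expected in this assay, though the uncertainty runs wide in both directions. The estimated step of a 1.2-fold higher number from compound 2 to compound 4 (0.06 log units; within the scatter) is accordingly small. For compound 4 the expected value is 3000 nM, with an estimated range from 900 nM to 11000 nM.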

Compound 4, half-maximal inhibitory concentration: 18300 nM
Compound 4: the middle estimate sits 6.1-fold (0.79 log units) below what was measured; the whole stated range lies below it.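

In this assay, 3,4-dihydroxyphenyl in place of 4-hydroxycyclohexyl on an oxygen on an aromatic ring gives a 7.0-fold higher number from compound 2 to compound 4 (0.85 log units; beyond the scatter), so the number read here depends on the group at this position. For the compounds shown here, this is the first readable step, as compound 1 and compound 3 stand at limits of the assay and differ from compound 2 in more than one place. Nothing shown accounts for the size of this step.

The change replaces a non-aromatic ring with an aromatic one and also adds a hydroxyl, and the compounds shown do not separate these two differences. Going by these compounds, how a 4-aminocyclohexyl, a 4-carboxyphenyl or a single-hydroxyl 4-hydroxyphenyl would read at this position remains open.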